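A Methyl Added Beside an Ethyl Neighbour: Compound 4

The source may hold more compounds than are shown below. What is called first, only, known or untested is meant among the compounds shown, and "the series" means these compounds.

Measured compounds:
- compound 1, `CCC(C(=O)N1CCN(c2ccccc2Cl)CC1)N1C(=O)CCC1=O`: 50%
- compound 2, `CCC(C(=O)N1CCN(c2cccc(OC)c2)CC1)N1C(=O)CCC1=O`: 0%
- compound 3, `CC(C(=O)N1CCN(c2ccccc2F)CC1)N1C(=O)CCC1=O`: 50%

In a functional assay on the whole organism (strain Swiss) with Mus musculus as the target, in the maximal electroshock model, with a stated time of 1 h, at a dose of 300 mg/kg by the intraperitoneal route (a higher number here means a stronger effect of the compound at the dose given, a lower number a weaker effect), compound 3 gives 50%, level with compound 1 at the digits shown, and the two together sit at the top of the three numbers. Going by the values given here, compound 2 lies far below: the step of a number 50 percentage points lower from compound 1 to compound 2 (beyond the scatter) is the only step charted here, and it concerns an aromatic group change, not the chain. Compound 4, `CCC(C(=O)N1CCN(c2ccccc2F)CC1)N1C(=O)CCC1=O`, has not yet been measured in this assay. It differs from compound 3 in one place: methyl in place of hydrogen on a saturated chain carbon, two bonds along the chain from an amide-type nitrogen in a ring and a carbonyl carbon.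

Among the compounds with values here, no charted step bears directly on this change. What the data do show is that compound 1, which already carries the longer chain, and compound 3, which carries the shorter one, give the same number in this assay even though their aromatic groups also differ. On that basis the step of no change at the digits printed from compound 3 to compound 4 (within the scatter) is expected to stay within the scatter. Compound 4 is therefore estimated at 50%, with a likely range from 25% to 75%.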

Compound 4, a percentage reported as activity, at one dose (the size of the read-out at that dose, not a potency): 50%
The estimate for compound 4 equals the measured number at the digits printed; low and high end bracket the measured number.
By their numbers in this assay, from the lowest: compound 2; then compounds 1, 3 and 4 (each within the scatter of the next).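

In this assay, going by these compounds alone, methyl in place of hydrogen on the saturated chain carbon gives no change at the digits printed from compound 3 to compound 4 (within the scatter), the first direct reading of this change with the 2-fluorophenyl group held fixed. Fluoro in place of chloro on an aromatic carbon gives no change at the digits printed from compound 1 to compound 4 (within the scatter), whereas 2-fluorophenyl in place of 3-methoxyphenyl gives a number 50 percentage points higher from compound 2 to compound 4 (beyond the scatter), so among these compounds the one large difference lies with the aromatic group and not with the chain. No measurement shown here offers a reason for these results.

A propyl or a hydroxymethyl group on this chain carbon could keep the number or lose it, and these compounds cannot tell which. As far as these compounds go, the read-out also comes from one dose, so differences that might appear at lower doses remain open.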